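The source may hold more compounds than are shown below. What is called first, only, known or untested is meant among the compounds shown, and "the series" means these compounds.

Measured so far:
compound 1 `CC(=O)Oc1ccc(CN(C(=O)COC(=O)c2ccc([N+](=O)[O-])o2)C(C)(C)C)cc1`: > 100000 nM
compound 2 `CC(C)(C)N(Cc1ccc(OCc2ccccc2)cc1)C(=O)COC(=O)c1ccc([N+](=O)[O-])o1`: "not active" (no number reported)

In an ADME assay on HEK-293T cells (Homo sapiens) for cytotoxicity, read by MTT assay, with a stated time of 3 days (on this read-out higher numbers stand for lower toxicity in this test and lower numbers for higher toxicity in this test), compound 1 gives > 100000 nM, which is a limit of the assay and not a number. Compound 2 has no single number and is reported as "not active" (no number reported). For the measured compounds named here, the only other reading is the limit of > 100000 nM in this assay, at which 1 of the 2 values shown sits.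

Compound 3 `CC(C)(C)N(Cc1ccc(C(F)(F)F)cc1)C(=O)COC(=O)c1ccc([N+](=O)[O-])o1` is the next structure. The change is trifluoromethyl in place of benzyloxy on an aromatic carbon, with trifluoromethyl in place of benzyloxy on an aromatic carbon, para to a large group. Going by the values given here, no measured step is available to size this change, and no shift beyond the scatter is expected in this assay. Compound 3 is expected at 90000 nM, with an estimated range of 30000 nM to 150000 nM.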

Compound 3, half-maximal cytotoxic concentration: 36000 nM
For compound 3 the middle estimate is 2.5-fold (0.40 log units) above the measured one; measured number inside the range.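

In this assay, for the compounds shown here, compound 3 gives 36000 nM as the first actual number of the series, and acetoxy giving way to trifluoromethyl on an aromatic carbon, para to a large group, is read as an at least 2.7-fold lower number from compound 1 to compound 3 (0.44 log units; beyond the scatter) in this assay. Compound 1 gives > 100000 nM which is a limit, so this step is a bound and not a full size: the limit of > 100000 nM in this assay, at which 1 of the 3 values shown sits. Compound 2 carries no number, so the change from benzyloxy to trifluoromethyl stays unsized. Open, from the compounds shown here alone, is how an amine or a carboxylic acid at this position would read in this assay on the same core.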